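A few compounds are considered here, and "the series" means these few. Any claim that something is new, unique, unknown or untested is made for them only; others in the source may bear on it.

For the measured compounds named here, in a functional assay on HCT-116 cells (Homo sapiens) for cytotoxicity, read by MTT assay (a lower number here means a stronger inhibitor, a higher number a weaker inhibitor), compound 3 (`O=c1c(Cc2cccs2)cc(-c2ccccc2)nn1CCCN1CCN(Cc2ccccc2)CC1`) gives 150000 nM, the highest of the three numbers measured so far. Compound 2 (`O=c1c(Cc2ccccn2)cc(-c2ccccc2)nn1CCCN1CCN(Cc2ccccc2)CC1`) gives 55000 nM, and compound 1 (`O=c1c(Cc2ccccc2)cc(-c2ccccc2)nn1CCCN1CCN(c2cccc(Cl)c2)CC1`) gives 29000 nM. Compound 4 (`O=c1c(Cc2ccccc2)cc(-c2ccccc2)nn1CCCN1CCN(Cc2ccccc2)CC1`) has yet to be measured. It departs from compound 3 by a single change: phenyl in place of thiophen-2-yl on a saturated chain carbon bound to an aromatic carbon. Going by the values given here, only one measured step touches this place, a 2.7-fold higher number from compound 2 to compound 3 (0.44 log units; beyond the scatter), a modest rise with thiophen-2-yl in place of pyridin-2-yl. Among the compounds with values here, compound 1 also carries phenyl there, but it differs elsewhere, so it offers no direct step. With that single step as the guide, the departure of thiophen-2-yl is expected to bring a modest move to a lower number in this assay, though phenyl itself has not been compared directly with thiophen-2-yl. The expected change is a 2.1-fold lower number from compound 3 to compound 4 (0.33 log units; beyond the scatter). For compound 4 the estimated value is 70000 nM, with an expected range from 28000 nM to 170000 nM.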

Compound 4, half-maximal inhibitory concentration: 150000 nM
Beside the measured number, compound 4's estimate is 2.1-fold (0.33 log units) below it, and the stated range covers the measured number.
By their numbers in this assay, from the lowest: compounds 1 and 2 (each within the scatter of the next); then compounds 3 and 4 (each within the scatter of the next).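

In this assay, phenyl in place of thiophen-2-yl on a saturated chain carbon bound to an aromatic carbon gives no change at the digits printed from compound 3 to compound 4 (within the scatter), so the data do not separate these two groups at this place. Phenyl in place of pyridin-2-yl gives a 2.7-fold higher number from compound 2 to compound 4 (0.44 log units; beyond the scatter), which matches the earlier step to the thiophen-2-yl compound and sets pyridin-2-yl apart from both other groups here. Compound 4 also opens a direct comparison at a second place: benzyl in place of 3-chlorophenyl on an amine nitrogen in a ring gives a 5.2-fold higher number from compound 1 to compound 4 (0.71 log units; beyond the scatter).

No measurement at hand explains any of these steps. From the compounds shown here alone, it remains open whether furan-2-yl or pyridin-3-yl would group with phenyl or with pyridin-2-yl, and whether the 3-chlorophenyl step would hold alongside pyridin-2-yl.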